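Cytotoxicity notes: chloro to heptylamino on the shared core

This account rests on a few compounds, and the source may have more. Where it says the series, first, only, none or still open, it means among the compounds named here.

Measured in an ADME assay on HeLa cells (Homo sapiens) for cytotoxicity, read by microscopy, with a stated time of 6 days; a lower number here means that less compound is tolerated, a higher number that more compound is tolerated:
compound 1 `CCCCNc1cncc(C(=O)NCc2ccccc2)n1` gives > 100000 nM, a limit of the assay.
compound 2 `CCCCCCCCNc1cncc(C(=O)NCc2ccccc2)n1` gives > 100000 nM, a limit of the assay.
compound 3 `O=C(NCc1ccccc1)c1cncc(Cl)n1` has "not determined" (no result reported), no result in this assay.

Compound 3 therefore stands nowhere on the numbers: no concentration is known for it, and the two values that exist in the series are both limits. Among the compounds with values here, the one step between measured compounds, a step that the two limits leave unreadable from compound 1 to compound 2, is unreadable for the same reason; the evidence is summed up in the limit of > 100000 nM in this assay, at which 2 of the 3 values shown sit. Both the butylamino and the octylamino analogues are tolerated up to the top of the tested range.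

Compound 4 `CCCCCCCNc1cncc(C(=O)NCc2ccccc2)n1` carries the change (heptylamino in place of chloro on an aromatic carbon). The heptylamino group is a chain of a length that falls between the chains of compound 1 and compound 2. Within the data shown here, no measured step bears on the change itself, since compound 3 has no value; what is known is only that the two alkylamino analogues sit at the limit. No step beyond the scatter is expected for compound 4 in this assay, and the most likely outcome is another limit. Compound 4 is estimated at 100000 nM, with a range of 50000 nM to 200000 nM.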

Compound 4, minimum cytotoxic concentration: > 100000 nM
Compound 4: a limit, no number; the forecaster's own chance of this, stated with the estimate: 85%; the middle value sits exactly at the limit.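

In this assay compound 4 gives > 100000 nM, a limit. Compound 1 and compound 2 also sit at limits, so no new step can be read among compound 1, compound 2 and compound 4. The series now reads: the limit of > 100000 nM in this assay, at which 3 of the 4 values shown sit.

The compounds shown leave open the concentration at which any of these three alkylamino analogues turns cytotoxic, and how compound 3 compares with them.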